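Methyl in Place of Chloro Against Three Limits

This account rests on a few compounds, and the source may have more. Where it says the series, first, only, none or still open, it means among the compounds named here.

Compound 2 `Cc1nc(Nc2cccc(Cl)c2)sc1C(=O)/C=C/c1ccccc1` is one of three compounds tested in a functional assay on Bel-7402 cells (Homo sapiens) for cytotoxicity, read by MTT assay (a higher number here means a weaker inhibitor, a lower number a stronger inhibitor), and its result there is only a limit, not a number. In this assay compound 2 gives > 25000 nM, a limit. Compound 1 `COc1cccc(/C=C/C(=O)c2sc(Nc3ccc(Cl)cc3)nc2C)c1` gives > 25000 nM, also a limit. Compound 3 `Cc1nc(Nc2cccc(Cl)c2)sc1C(=O)/C=C/c1ccc(Cl)cc1` gives > 25000 nM, again a limit. Among the compounds with values here, the single step between measured compounds therefore reads as a step that the two limits leave unreadable from compound 2 to compound 3. Compound 4 `Cc1cccc(Nc2nc(C)c(C(=O)/C=C/c3ccccc3)s2)c1` differs from compound 2 by methyl in place of chloro on an aromatic carbon. Within the data shown here, no measured step can guide this change, because the limit of > 25000 nM in this assay, at which 3 of the 3 values shown sit, is all the measurements show. Compound 4 is therefore expected to remain at the limit, a step that the limit leaves unreadable from compound 2 to compound 4. The estimate for compound 4 is 40000 nM, within a range of 10000 nM to 200000 nM.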

Compound 4, half-maximal inhibitory concentration: > 25000 nM
Compound 4 ended at the assay's limit; the forecaster's own chance of this, stated with the estimate: 85%; the middle value does not contradict the limit.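

Compound 4 sits at the same limit as compound 2, so no new step can be read between them: the limit of > 25000 nM in this assay, at which 4 of the 4 values shown sit.

The compounds shown leave open how strongly any of them acts in this assay and whether methyl and chloro differ there.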